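Swapping the halobenzyl group: a cytotoxicity estimate

The source may hold more compounds than are shown below. What is called first, only, known or untested is meant among the compounds shown, and "the series" means these compounds.

Compound 1 `O=c1ccoc2cc(OCc3cn(Cc4cccc(F)c4)nn3)ccc12`: in an ADME assay on L02 cells (Homo sapiens) for cytotoxicity, read by MTT assay, with a stated time of 48 h (on this read-out higher numbers stand for weaker inhibition and lower numbers for stronger inhibition), compound 1 gives > 300000 nM, a limit of the assay.
Compound 2 `O=c1ccoc2cc(OCc3cn(Cc4cccc(Br)c4)nn3)ccc12`: in this assay compound 2 gives > 300000 nM, a limit of the assay.
Compound 3 `C#CCOc1ccc2c(=O)ccoc2c1`: in this assay compound 3 gives > 300000 nM, a limit of the assay.

Compound 2 therefore stands only at a limit, like every other value shown. For the measured compounds named here, the one measured step, a step that the two limits leave unreadable from compound 1 to compound 2, is unreadable because of the limit of > 300000 nM in this assay, at which 3 of the 3 values shown sit. Compound 4 `O=c1ccoc2cc(OCc3cn(Cc4ccc(F)cc4)nn3)ccc12` differs from compound 2 by 4-fluorophenyl in place of 3-bromophenyl on a saturated chain carbon bound to an aromatic nitrogen. Going by the values given here, no measured step bears on this change in a readable way, so no step beyond the scatter is expected in this assay in either direction; the estimated step that the limit leaves unreadable from compound 2 to compound 4 is near zero. Compound 4 is expected to give about 400000 nM, in a range from 150000 nM to 1200000 nM, most likely again as a limit.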

Compound 4, half-maximal inhibitory concentration: > 300000 nM
Compound 4 was reported as a limit; the forecaster's own chance of this, stated with the estimate: 85%; the middle value is on the limit's open side.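

For the compounds shown here, no step to compound 4 from compound 1 or compound 2 can be read in this assay, because all three stand only as limits: the limit of > 300000 nM in this assay, at which 4 of the 4 values shown sit. The compounds shown leave open the size of any difference among them in this read-out.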